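Cyclic Ketone in Place of an Amide Chain

The source may hold more compounds than are shown below. What is called first, only, known or untested is meant among the compounds shown, and "the series" means these compounds.

Measured in an assay for inhibition of serine/threonine-protein kinase Sgk1 (Homo sapiens), with stated times of 30 min and 60 min, in the presence of a further agent that is not named here; a lower number here means a stronger inhibitor, a higher number a weaker inhibitor:
- compound 1, `CCNC(=O)c1cc(-c2ccc(NS(=O)(=O)c3cccc(Cl)c3Cl)cc2)nc2[nH]ncc12`, gives 6 nM
- compound 2, `Cc1n[nH]c2nc(-c3ccc(NS(=O)(=O)c4cc(Cl)ccc4F)cc3)nc(OCCC(=O)N(C)C)c12`, gives 15 nM

Going by the values given here, of the two measured compounds, compound 2 carries the higher number in this assay; its only neighbour, compound 1, sits at a lower number, and that gap lies beyond the usual scatter. The two structures differ in several places at once, so nothing can be read from their pair about any single change.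

Compound 3, `Cc1n[nH]c2nc(-c3ccc(NS(=O)(=O)c4cc(Cl)ccc4F)cc3)nc(OC3CCC(=O)CC3)c12`, is built from compound 2 by one change: 4-oxocyclohexyl in place of 2-(dimethylcarbamoyl)ethyl on an oxygen on an aromatic ring. Among the compounds with values here, no pair of measured compounds shares this change, so the expectation rests on compound 2 alone. The step of a 1.3-fold higher number from compound 2 to compound 3 (0.12 log units; within the scatter) is expected to stay within the scatter, with no direction that can be argued from the data. Compound 3 is therefore estimated at 20 nM, with a range from 7 nM to 60 nM.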

Compound 3, half-maximal inhibitory concentration: 5 nM
Beside the measured number, compound 3's estimate is 4.0-fold (0.60 log units) above it; the measured number lies below the stated range.
By their numbers in this assay, from the lowest: compounds 3 and 1 (each within the scatter of the next); then compound 2.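

On an oxygen on an aromatic ring, the open 2-(dimethylcarbamoyl)ethyl chain can give way to the 4-oxocyclohexyl ring with no loss in this assay: the exchange gives a 3.0-fold lower number from compound 2 to compound 3 (0.48 log units; beyond the scatter). The two groups match in their counts of heavy atoms and hydrogen-bond acceptors, so this position responds to a difference that those counts do not capture, such as the amide nitrogen leaving or the carbon ring entering. No measurement shown ties the step to any property of either group.

As far as these compounds go, it remains open whether the ketone matters or only the ring, a question that a hydroxyl or an amine in place of the ketone, or a plain cyclohexyl, could help to settle. From the compounds shown here alone, it is also open whether the same exchange would hold on the core of compound 1.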